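The source may report more compounds than this note shows. Statements on the series, on what has been measured and on what is new or still open speak of the compounds shown alone.

Measured compounds in a functional assay on K562 cells (Homo sapiens), read by MTT assay, with a stated time of 72 h; a lower number here means a stronger inhibitor, a higher number a weaker inhibitor:
Compound 1 `Cc1ncnc2c1c(-c1cccs1)cn2[C@@H]1O[C@H](CO)[C@@H](O)[C@H]1O` gives > 20000 nM, which is a limit of the assay rather than a number.
Compound 2 `CSc1ncnc2c1c(-c1cccs1)cn2[C@@H]1O[C@H](CO)[C@@H](O)[C@H]1O` gives > 20000 nM, again a limit.
Compound 3 `CN(C)c1ncnc2c1c(-c1cccs1)cn2[C@@H]1O[C@H](CO)[C@@H](O)[C@H]1O` gives > 20000 nM, also a limit.

Compound 1 therefore stands only at a limit in this assay, and the same holds for the two compounds around it. The steps a step that the two limits leave unreadable from compound 1 to compound 2, a step that the two limits leave unreadable from compound 1 to compound 3 and a step that the two limits leave unreadable from compound 2 to compound 3 cannot be sized, since every value in this set sits at the same place, as summed up by the limit of > 20000 nM in this assay, at which 3 of the 3 values shown sit.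

Compound 4 `Cc1ncnc2c1c(I)cn2[C@@H]1O[C@H](CO)[C@@H](O)[C@H]1O` has not yet been measured. It differs from compound 1 in one way: iodo in place of thiophen-2-yl on an aromatic carbon. Among the measured compounds shown here, none of the measured steps changes the same part of the shared core, so none bears directly on this change, and the measured compounds give no readable step of any size or direction. What they do show is that three variations of the core all remained at the limit. For compound 4 the expectation is therefore a value near that limit, with the step that the limit leaves unreadable from compound 1 to compound 4 expected to stay within scatter, so compound 4 is estimated at 30000 nM, within 5000 nM to 200000 nM.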

Compound 4, half-maximal inhibitory concentration: > 20000 nM
Compound 4 gave a limit, no number; the forecaster's own chance of this, stated with the estimate: 75%; the middle value lies beyond the limit too.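

Compound 4, like compound 1, gives a limit rather than a number, so the change from compound 1 to compound 4 cannot be sized, and neither can any other step here: the limit of > 20000 nM in this assay, at which 4 of the 4 values shown sit.

The compounds shown leave open whether any change to the shared core would give a readable value.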